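The source may hold more compounds than are shown below. What is called first, only, known or untested is meant among the compounds shown, and "the series" means these compounds.

Measured in an ADME assay on HepG2 cells (Homo sapiens) for cytotoxicity, read by CellTiter-Glo, with a stated time of 72 h; on this read-out higher numbers stand for an effect only at larger amounts of compound and lower numbers for an effect already at smaller amounts:
- compound 1 `CCOC(=O)CNC(=O)[C@H](CS[C@H]1[C@@H]2C(=O)/C(C)=C\C3=C[C@H](C)C[C@@]34O[C@]2(CC1(C)C)[C@@H](C)C4=O)NC(=O)CC[C@H](N)C(=O)O`: 26000 nM
- compound 2 `CC1=C2CC(C)(C)/C=C/C(=O)/C(C)=C\C3=C[C@H](C)C[C@]3(O2)[C@@]1(O)C(F)(F)F`: 26000 nM
- compound 3 `CC1=C2CC(C)(C)/C=C/C(=O)/C(C)=C\C3=C[C@H](C)C[C@]3(O2)[C@]1(C)O`: 26000 nM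

Going by the values given here, on these numbers, compound 3 stands level with compounds 1 and 2, and no measured compound separates from the others. Compound 4 `CC1=C2CC(C)(C)/C=C/C(=O)/C(C)=C\C3=C[C@H](C)C[C@]3(O2)[C@@]1(O)C#N` carries cyano in place of methyl on a saturated ring carbon. Among the compounds with values here, the one measured step that bears on this change is no change at the digits printed from compound 2 to compound 3 (within the scatter), which exchanges methyl and trifluoromethyl on that same carbon. Compound 1 has a different core and says little about it. No step beyond the scatter is therefore expected in this assay, in either direction. The expected change is no change at the digits printed from compound 3 to compound 4 (within the scatter). For compound 4 the estimated value is 26000 nM, with an expected range of 12000 nM to 40000 nM.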

Compound 4, half-maximal effective concentration: 26000 nM
For compound 4 middle estimate and measured number coincide at the digits printed, within the range that was stated.
By their numbers in this assay, from the lowest: compounds 1, 2, 3 and 4 (each within the scatter of the next).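

In this assay, putting cyano in place of methyl on this saturated ring carbon gives no change at the digits printed from compound 3 to compound 4 (within the scatter), and putting cyano in place of trifluoromethyl gives no change at the digits printed from compound 2 to compound 4 (within the scatter). A group with a triple bond and a hydrogen-bond acceptor thus joins methyl and trifluoromethyl at this carbon without separating from them, so all three pairs among these groups are now measured. Nothing shown accounts for this flat result.

On these data alone, whether an amine, a carboxylic acid or a longer chain on this same carbon would stay level with these compounds remains open.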